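Removing the Amide Methyl: Compound 3 Expected Near Compound 2

A few compounds are considered here, and "the series" means these few. Any claim that something is new, unique, unknown or untested is made for them only; others in the source may bear on it.

Compound 1, `C/N=C(\S)CCn1nc(-c2ccccc2)ccc1=O`: 68.2%
Compound 2, `CNC(=O)CCn1nc(-c2ccccc2)ccc1=O`: 3.5%

Both compounds were tested in a functional assay on the whole organism (stomach) for inhibition, with Rattus norvegicus as the target, at a dose of 100 mg/kg by the intraduodenal route; a higher number here means more inhibition at the dose given (going by the name of the read-out), a lower number less inhibition. Among the compounds with values here, compound 2 gives the lower of the two numbers, 3.5%, and the only step between measured compounds, a number 64.7 percentage points lower from compound 1 to compound 2 (beyond the scatter), is the swap of the thioamide-type group for the amide-type group.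

Compound 3, `NC(=O)CCn1nc(-c2ccccc2)ccc1=O`, has not been measured. It differs from compound 2 only by hydrogen in place of methyl on an amide-type nitrogen. Within the data shown here, no measured step touches this part of the molecule, so there is no direct guide; the one step recorded concerns a different exchange and says nothing about trimming the methyl group. Since compound 2 already sits near the bottom of what this assay can report with 3.5%, the expected step of a number 4.5 percentage points higher from compound 2 to compound 3 (within the scatter) is small, within the usual scatter. Compound 3 is therefore estimated at 8%, with a range from 0% to 30%.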

Compound 3, a percentage reported as inhibition, in the whole organism at one dose (the size of the read-out at that dose, not a potency): -2.8%
Compound 3: middle estimate off by 10.8 percentage points, on the high side, outside the stated range (below it).
By their numbers in this assay, from the lowest: compounds 3 and 2 (each within the scatter of the next); then compound 1.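

In this assay, going from methylamino to amino gives a number 6.3 percentage points lower from compound 2 to compound 3 (within the scatter) and so leaves the read-out unchanged within the scatter: at this amide-type nitrogen, neither methyl nor hydrogen lifts the inhibition at the dose given. The comparison with the sulfur-containing compound gives a number 71 percentage points lower from compound 1 to compound 3 (beyond the scatter) and shows that the large gap first seen with compound 2 remains when the amide-type nitrogen carries only hydrogen. No supporting measurement bears on the reason for either result.

From the compounds shown here alone, whether the methyl group matters when sulfur is kept remains open, as the sulfur-containing group appears here only with methyl on its nitrogen. It is also unknown how an ethyl group on this nitrogen, or a carboxylic acid in place of the whole amide group, would perform in this assay at this position.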